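The source may hold more compounds than are shown below. What is called first, only, known or untested is meant among the compounds shown, and "the series" means these compounds.

Measured compounds in a functional assay on M21 cells (Homo sapiens) for antiproliferative activity, with a stated time of 48 h; on this read-out higher numbers stand for weaker inhibition and lower numbers for stronger inhibition:

- compound 1 `CCCCC(O)c1cccc(NC(=O)NC(=O)CCl)c1`: 4600 nM
- compound 2 `CCCCC(O)c1cccc(NC(=O)CCCl)c1`: > 100000 nM (a limit of the assay, not a number)
- compound 3 `CCCCCc1cccc(NC(=O)CCCCl)c1`: > 100000 nM (a limit of the assay, not a number)

Compound 3 stands at the limit (the limit of > 100000 nM in this assay, at which 2 of the 3 values shown sit); no number is known for it. Compound 2 sits at that same limit. Within the data shown here, compound 1 alone gives a number, and the one step that differs in a single place, an at least 21-fold higher number from compound 1 to compound 2 (1.33 log units; beyond the scatter), concerns the acyl part rather than the side chain carbon.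

Compound 4 `CCCCC(O)c1cccc(NC(=O)CCCCl)c1` is not yet measured. Its difference from compound 3 is hydroxy in place of hydrogen on a saturated chain carbon bound to an aromatic carbon and a saturated chain carbon. Among the measured compounds shown here, no measured pair isolates this change: the hydroxy group is present in compound 1 and compound 2 and absent in compound 3, but those compounds also differ in the acyl part, so no step bears directly on the move from compound 3 to compound 4.

For the measured compounds named here, with the starting point itself a limit and no step to lean on, compound 4 is expected to stay at or near the limit, with an expected step of a number no higher from compound 3 to compound 4 (the limit leaves the size open). The estimate for compound 4 in this assay is 100000 nM, within 30000 nM to 300000 nM.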

Compound 4, half-maximal inhibitory concentration: > 100000 nM
Compound 4: only a limit was reported; the forecaster's own chance of this, stated with the estimate: 70%; the middle value lies on the limit itself.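

In this assay compound 4 sits at a limit of the assay, > 100000 nM, and this is not a number. The steps from compound 3 and from compound 2 cannot be read, so the hydroxy in place of hydrogen on the saturated chain carbon has no measurable size here, though the 1-hydroxypentyl chain alone does not bring the 3-chloropropyl group on the carbonyl carbon off the limit. With that chain kept, an at least 21-fold higher number from compound 1 to compound 4 (1.33 log units; beyond the scatter) stands alongside an at least 21-fold higher number from compound 1 to compound 2 (1.33 log units; beyond the scatter), so both acyl changes away from compound 1 end at the same limit: the limit of > 100000 nM in this assay, at which 3 of the 4 values shown sit.

From the compounds shown here alone, whether pentyl to 1-hydroxypentyl matters with the acyl part of compound 1, where a number can be read, stays open. Also open, going by these compounds, is how an amine or a carboxylic acid at that chain carbon, or a longer chain, would read in this assay.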